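This account rests on a few compounds, and the source may have more. Where it says the series, first, only, none or still open, it means among the compounds named here.

compound 1 `O=C(/C=C/c1ccccc1)NNC(=O)c1ccc2c(c1)OCCO2` gives 550 nM
compound 2 `Cc1ccccc1/C=C/C(=O)NNC(=O)c1ccc2c(c1)OCCO2` gives 7710 nM
compound 3 `O=C(/C=C/c1cccc(F)c1)NNC(=O)c1ccc2c(c1)OCCO2` gives 4110 nM

Compound 1 stands lowest of the three in a functional assay on cells (Cancer cell lines, Homo sapiens) for inhibition, read by MTT assay, with a stated time of 48 h (a lower number here means a stronger inhibitor, a higher number a weaker inhibitor), with 550 nM as its value, and both other compounds lie beyond the scatter from it. Compound 4 `O=C(/C=C/c1ccccc1Cl)NNC(=O)c1ccc2c(c1)OCCO2` is not yet measured. It differs from compound 1 by chloro in place of hydrogen on an aromatic carbon in a single change: chloro in place of hydrogen on an aromatic carbon, ortho to a large group, which reads phenyl to 2-chlorophenyl.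

For the measured compounds named here, two measured steps bear on this change. One is a 14-fold higher number from compound 1 to compound 2 (1.15 log units; beyond the scatter) for methyl in place of hydrogen on an aromatic carbon, and it is large. The other is a 7.5-fold higher number from compound 1 to compound 3 (0.87 log units; beyond the scatter) for fluoro in place of hydrogen on an aromatic carbon, and it is modest. The step of a 1.9-fold lower number from compound 2 to compound 3 (0.27 log units; within the scatter) stays within the scatter, so these two substituted compounds do not separate. Going by the values given here, no chloro compound has been measured.

A step of comparable size toward a higher number is therefore expected in this assay for the new compound. The expected step is a 9.1-fold higher number from compound 1 to compound 4 (0.96 log units; beyond the scatter) in the direction of a weaker inhibitor. For compound 4 the estimated value is 5000 nM with an expected range of 1500 nM to 14000 nM for repeat measurements.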

Compound 4, half-maximal inhibitory concentration: 4880 nM
For compound 4 the middle estimate is 1.0-fold (0.01 log units) above the measured one; measured number inside the range.
By their numbers in this assay, from the lowest: compound 1; then compounds 3, 4 and 2 (each within the scatter of the next).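

In this assay, chloro in place of hydrogen on an aromatic carbon, ortho to a large group, gives an 8.9-fold higher number from compound 1 to compound 4 (0.95 log units; beyond the scatter) and so adds a third substituted phenyl compound on the weaker side of compound 1. The new compound does not separate from the earlier substituted pair: the comparison with the 3-fluorophenyl compound gives a 1.2-fold higher number from compound 3 to compound 4 (0.07 log units; within the scatter) and chloro in place of methyl gives a 1.6-fold lower number from compound 2 to compound 4 (0.20 log units; within the scatter) and both steps stay within the scatter, so the three substituents shown read alike in this assay while none comes near unsubstituted phenyl. No measurement shown here accounts for the loss on substitution or for the likeness of the three substituted compounds.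

Still open, going by these compounds, is whether any substituent on this ring can hold the level of compound 1 at 550 nM in this series, for example an amine, a carboxylic acid or a methoxy group. The compounds shown also never carry one group at two different places on the ring, so the contribution of the group cannot be told apart from that of its place.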